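Phenyl for Cyclohexyl in a Tolerated Series

The source may hold more compounds than are shown below. What is called first, only, known or untested is meant among the compounds shown, and "the series" means these compounds.

Compound 1 `CCC1=C(C(=O)CCC2CCCC2)[C@H](c2ccc(O)c(Cl)c2)NC(=O)N1` in an ADME assay on cells (Homo sapiens) for cytotoxicity (a lower number here means that less compound is tolerated, a higher number that more compound is tolerated), gives a limit of > 10000 nM.
Compound 2 `CCC1=C(C(=O)CCC2CCCCC2)[C@H](c2ccc(O)c(Cl)c2)NC(=O)N1` in this assay gives a limit of > 10000 nM.

Compound 2 stands at the assay limit, at which both shown values sit (the limit of > 10000 nM in this assay, at which 2 of the 2 values shown sit). The measured step that the two limits leave unreadable from compound 1 to compound 2 is unreadable between the two limits. Compound 3 `CCC1=C(C(=O)CCc2ccccc2)[C@H](c2ccc(O)c(Cl)c2)NC(=O)N1` differs from compound 2 by phenyl in place of cyclohexyl on a saturated chain carbon, two bonds along the chain from a carbonyl carbon. Within the data shown here, no measured step bears on this change, and the single measured step is not readable. He therefore expects no readable step beyond the scatter, estimated as a step that the limit leaves unreadable from compound 2 to compound 3. For compound 3 he expects 15000 nM, with a range from 5000 nM to 50000 nM, most likely again reported as a limit.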

Compound 3, half-maximal cytotoxic concentration: > 10000 nM
Compound 3: a limit, no number; the forecaster's own chance of this, stated with the estimate: 80%; the middle value is on the limit's open side.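

In this assay compound 3 gives > 10000 nM, which is a limit. No step among compound 1, compound 2 and compound 3 can be read: the limit of > 10000 nM in this assay, at which 3 of the 3 values shown sit.

Left open is whether these three compounds differ at all in this assay, since none has a value beyond the limit.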